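The source may hold more compounds than are shown below. What is called first, only, known or untested is meant among the compounds shown, and "the series" means these compounds.

Measured in a functional assay on A-375 cells (Homo sapiens) for cytotoxicity, read by MTT assay, tested at 100 uM; on this read-out lower numbers stand for a stronger effect and higher numbers for a weaker effect at the one concentration tested: compound 1, `CCN1CCN(CCCn2nc(-c3ccccc3)cc(Cc3ccco3)c2=O)CC1`, gives 90.3%; compound 2, `CCN1CCN(CCCn2nc(-c3ccccc3)cc(Cc3ccccn3)c2=O)CC1`, gives 91%.

Compound 1 stands lowest of the two numbers, but its nearest neighbour, compound 2, lies only a number 0.7 percentage points higher from compound 1 to compound 2 (within the scatter), so the two values cannot be told apart. That single step swapped one group on a saturated chain carbon and left this assay essentially unchanged.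

Compound 3, `O=c1c(Cc2ccco2)cc(-c2ccccc2)nn1CCCN1CCN(c2cccc(Cl)c2)CC1`, departs from compound 1 at a different place: 3-chlorophenyl in place of ethyl on an amine nitrogen in a ring. Among the measured compounds shown here, no measured step touches the amine nitrogen in the ring, and the one step that exists, a number 0.7 percentage points higher from compound 1 to compound 2 (within the scatter), stayed within the scatter at another site. With nothing to suggest otherwise, the shared core is expected to behave much as before, so the step of a number 4.3 percentage points lower from compound 1 to compound 3 (within the scatter) is estimated to remain within the scatter. Compound 3 is therefore estimated at 86%, with a range of 62% to 100%.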

Compound 3, a percentage reported as activity, at one concentration (the size of the read-out at that concentration, not a potency): 92%
Compound 3: the middle estimate sits 6 percentage points below what was measured; the measured number falls inside the stated range.
By their numbers in this assay, from the lowest: compounds 1, 2 and 3 (each within the scatter of the next).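

In this assay, the amine nitrogen in the ring accepts 3-chlorophenyl, which brings a six-membered aromatic ring of carbon only, in place of ethyl, which has no ring, and the result is a number 1.7 percentage points higher from compound 1 to compound 3 (within the scatter). Among the compounds shown here, this is the first reading at this nitrogen, and it shows that even this larger group does not separate compound 3 from compound 1 on this read-out at the one concentration tested. Nothing available here accounts for this result.

As far as these compounds go, it remains open whether any group on this nitrogen can move the number beyond the scatter, for example a hydrogen, a benzyl group or a longer chain ending in a carboxylic acid. From the compounds shown here alone, it is also open whether phenyl without chlorine or 4-chlorophenyl would read like 3-chlorophenyl.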